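The compounds below may be only part of what the source reports. "The series", "measured", "known", "first", "only" and "open" are said of these compounds alone.

Compound 1 `CC(=O)Oc1ccc2cc(-c3ccccc3)c(=O)oc2c1OC(C)=O` gives 8560 nM in an assay on CHO cells for displacement of a labelled ligand from adenosine receptor A1 (Homo sapiens), read by radioligand binding; a lower number here means a stronger inhibitor, a higher number a weaker inhibitor.
Compound 2 `CC(=O)Oc1ccc(-c2cc3ccc(OC(C)=O)c(OC(C)=O)c3oc2=O)cc1` gives > 100000 nM in this assay, which is a limit of the assay and not a number.

Compound 2 therefore stands at the limit of > 100000 nM in this assay, at which 1 of the 2 values shown sits, the weaker end of the two results. Compound 3 `CC(=O)Oc1ccc(-c2cc3ccc(OC(C)=O)c(OC(C)=O)c3oc2=O)cc1OC(C)=O` differs from compound 2 by acetoxy in place of hydrogen on an aromatic carbon. For the measured compounds named here, the only measured step of this kind is an at least 11-fold higher number from compound 1 to compound 2 (1.06 log units; beyond the scatter), large and toward weaker binding, its full size hidden by the limit. A further step in the same direction, or none beyond the scatter, is expected. Compound 3 is estimated at 200000 nM (range 60000 nM to 1000000 nM), meaning a step that the limit leaves unreadable from compound 2 to compound 3, most likely reported again only as a limit.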

Compound 3, inhibition constant: > 100000 nM
Compound 3: a limit, no number; the forecaster's own chance of this, stated with the estimate: 90%; the middle value does not contradict the limit.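

Compound 2 and compound 3 both give only a limit, not a number, so no step between them can be read: the limit of > 100000 nM in this assay, at which 2 of the 3 values shown sit.

The compounds shown leave open whether acetoxy in place of hydrogen changes binding from compound 2 to compound 3 at all.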